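The source may hold more compounds than are shown below. What is called first, only, known or untested is meant among the compounds shown, and "the series" means these compounds.

Measured compounds in a functional assay (brain) for displacement of a labelled ligand, with Rattus norvegicus as the target; a higher number here means a weaker inhibitor, a lower number a stronger inhibitor: compound 1 `NC[C@H]1COC(c2ccccc2)(c2ccccc2)O1` gives 1400 nM; compound 2 `CCC[C@H](NC)[C@H]1COC(c2ccccc2)(c2ccccc2)O1` gives 7000 nM.

Compound 2 stands with the highest number of the two, the nearest being compound 1 at the step of a 5.0-fold higher number from compound 1 to compound 2 (0.70 log units; beyond the scatter). Compound 3 `CCN[C@@H](C)[C@H]1COC(c2ccccc2)(c2ccccc2)O1` differs from compound 2 by 1-(ethylamino)ethyl in place of 1-(methylamino)butyl on a saturated ring carbon. For the measured compounds named here, the only step that bears on this change is a 5.0-fold higher number from compound 1 to compound 2 (0.70 log units; beyond the scatter), a modest one, and the change here is smaller in size. The number for compound 3 is therefore expected to move part of the way back, a step of a 1.8-fold lower number from compound 2 to compound 3 (0.24 log units; within the scatter). Compound 3 is estimated at 4000 nM, in the range 1500 nM to 10000 nM.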

Compound 3, inhibition constant: 9000 nM
Compound 3: the middle estimate sits 2.3-fold (0.35 log units) below what was measured, and the stated range covers the measured number.
By their numbers in this assay, from the lowest: compound 1; then compounds 2 and 3 (each within the scatter of the next).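

In this assay, placing 1-(ethylamino)ethyl instead of 1-(methylamino)butyl on this saturated ring carbon gives a 1.3-fold higher number from compound 2 to compound 3 (0.11 log units; within the scatter) and so does not separate the two side chains. Replacing aminomethyl with 1-(ethylamino)ethyl gives a 6.4-fold higher number from compound 1 to compound 3 (0.81 log units; beyond the scatter) in the same direction as a 5.0-fold higher number from compound 1 to compound 2 (0.70 log units; beyond the scatter) and shows that the earlier rise is not confined to one side chain. No measured evidence accounts for this result.

The compounds shown leave open whether the rise follows from the added carbon substituent or the substituted nitrogen. 1-Aminoethyl and methylaminomethyl groups would separate these two changes.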